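Adding a Methoxy Arm to a Lipophilicity Series

This account rests on a few compounds, and the source may have more. Where it says the series, first, only, none or still open, it means among the compounds named here.

Of the compounds shown here, three in this set have been measured in a physicochemical assay for lipophilicity, using the shake flask method; on this read-out lower numbers stand for lower lipophilicity and higher numbers for higher lipophilicity. Compound 1 `CC(C)Oc1cc(Oc2cnc(C(=O)N(C)C)nc2)cc(-c2nccc(=O)[nH]2)c1` gives 0.97 in this assay. Compound 2 `CC(C)Oc1cc(Oc2cnc(C(=O)N(C)C)cn2)cc(-c2nccc(=O)[nH]2)c1` is built from the same atoms as compound 1, joined differently; how the two cores differ is not broken down here. In this assay compound 2 gives 1.34, the highest of the three values, and its gap to compound 1 lies beyond the usual scatter. Compound 3 `COC[C@H](C)Oc1cc(Oc2cnc(C(=O)N(C)C)nc2)cc(-c2nccc(=O)[nH]2)c1` carries the core of compound 1 with one change, (methoxy in place of hydrogen on a saturated chain carbon, two bonds along the chain from an oxygen on an aromatic ring). In this assay compound 3 gives 0.43, which is a number 0.54 log units lower from compound 1 to compound 3 (beyond the scatter).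

Compound 4 `COC[C@H](C)Oc1cc(Oc2cnc(C(=O)N(C)C)cn2)cc(-c2nccc(=O)[nH]2)c1` has not yet been measured. It relates to compound 2 exactly as compound 3 relates to compound 1, through (methoxy in place of hydrogen on a saturated chain carbon, two bonds along the chain from an oxygen on an aromatic ring). The place of the change is described in the same words for both pairs, so this is the same change made on a core that differs in a way not broken down here. That change has occurred once so far among these compounds.

The step from compound 2 to compound 4 is expected to be roughly a number 0.54 log units lower from compound 2 to compound 4 (beyond the scatter), because the same change earlier produced a number 0.54 log units lower from compound 1 to compound 3 (beyond the scatter). This expectation rests on a single prior example, so it carries some uncertainty. Compound 4 is therefore estimated at 0.8 in this assay, most likely between 0.5 and 1.1.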

Compound 4, distribution coefficient: 0.81
Estimate against measurement, compound 4: 0.01 log units below; the measured number falls inside the stated range.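

In this assay the swap of isopropoxy to 1-(methoxymethyl)ethoxy gives a number 0.53 log units lower from compound 2 to compound 4 (beyond the scatter) and, on the other core, a number 0.54 log units lower from compound 1 to compound 3 (beyond the scatter) in the first pair's case; these two steps are of much the same size, so the change carried over from one core to the other with its size intact. This rests on just two matched pairs, so it shows that the step holds across these two cores, but it does not show that the step would hold on any further core or in any other kind of test. Nothing in the data offers a reason for the drop in either pair, so the match in size is an observation and not an explanation.

The compounds shown leave open how other groups would behave at the same place, on a saturated chain carbon two bonds along the chain from an oxygen on an aromatic ring, such as an amine, a carboxylic acid or a longer chain ending in ethoxy. They also leave open whether the mirror-image form of the 1-(methoxymethyl)ethoxy group would give a step of the same size on either core.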